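This account rests on a few compounds, and the source may have more. Where it says the series, first, only, none or still open, it means among the compounds named here.

Measured so far:
compound 1 `O=c1[nH]cc(S(=O)(=O)Nc2cccc(-c3cn(-c4ccccc4)nn3)c2)c(=O)[nH]1` — > 20000 nM
compound 2 `O=c1[nH]cc(S(=O)(=O)Nc2cccc(-c3cn(-c4ccccc4Cl)nn3)c2)c(=O)[nH]1` — 5370 nM

In a functional assay on OVCAR-3 cells (Homo sapiens) for antiproliferative activity, read by MTT assay, with a stated time of 24 h (on this read-out higher numbers stand for weaker inhibition and lower numbers for stronger inhibition), compound 1 reaches only a limit, > 20000 nM. Compound 2 gives 5370 nM, the only number shown. The other value, that of compound 1, is a limit (the limit of > 20000 nM in this assay, at which 1 of the 2 values shown sits). Going by the values given here, the one measured step, an at least 3.7-fold lower number from compound 1 to compound 2 (0.57 log units; beyond the scatter), is a chloro in place of hydrogen on the phenyl. Compound 3 `O=c1[nH]cc(S(=O)(=O)Nc2cccc(-c3cn(-c4cccc(Cl)c4)nn3)c2)c(=O)[nH]1` differs from compound 2 by 3-chlorophenyl in place of 2-chlorophenyl on an aromatic nitrogen. Among the compounds with values here, no measured step moves a chloro from one position to another, so that step gives no direction. Compound 3 is therefore expected near compound 2, at 4500 nM (range 1500 nM to 15000 nM), a step of a 1.2-fold lower number from compound 2 to compound 3 (0.08 log units; within the scatter) that is estimated to lie within the scatter.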

Compound 3, half-maximal inhibitory concentration: 3410 nM
Compound 3: the middle estimate sits 1.3-fold (0.12 log units) above what was measured, within the range that was stated.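

In this assay the 3-chlorophenyl and 2-chlorophenyl groups cannot be told apart, with a 1.6-fold lower number from compound 2 to compound 3 (0.20 log units; within the scatter). The gain over the unsubstituted phenyl therefore holds for a second placement of the chloro, with an at least 5.8-fold lower number from compound 1 to compound 3 (0.76 log units; beyond the scatter). The value of compound 1 is a limit, not a number: the limit of > 20000 nM in this assay, at which 1 of the 3 values shown sits.

On these data alone, whether a fluoro, a methoxy or an amine in place of the chloro on this phenyl would serve as well remains open.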